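This account rests on a few compounds, and the source may have more. Where it says the series, first, only, none or still open, it means among the compounds named here.

In a functional assay on ZR-75-1 cells (Homo sapiens) for inhibition, read by sulforhodamine B assay (on this read-out lower numbers stand for stronger inhibition of growth and higher numbers for weaker inhibition of growth), compound 1 (`COc1ccc(-c2ccc(-c3ccc(-c4nc5cc(C)ccc5[nH]4)cc3)cc2)cc1OC`) gives 3100 nM, the second highest of three numbers. Compound 2 (`COc1cc(-c2ccc(-c3ccc(-c4nc5cc(C)ccc5[nH]4)cc3)cc2)cc(OC)c1OC`) gives 190 nM, and compound 3 (`COc1ccc(-c2ccc(-c3ccc(-c4nc5ccccc5[nH]4)cc3)cc2)cc1OC`) gives 39700 nM. Compound 4 (`Cc1ccc2[nH]c(-c3ccc(-c4ccc(-c5ccc(OC(F)(F)F)cc5)cc4)cc3)nc2c1`) has not been measured, and it differs from compound 1 in one place: 4-(trifluoromethoxy)phenyl in place of 3,4-dimethoxyphenyl on an aromatic carbon. Among the measured compounds shown here, no measured step makes this exact swap. The closest is a 16-fold lower number from compound 1 to compound 2 (1.21 log units; beyond the scatter), a change in the same methoxy-bearing group, and it shows that edits there can matter. The other, a 13-fold higher number from compound 1 to compound 3 (1.11 log units; beyond the scatter), removes a methyl that compound 4 keeps, so it bears only on how large single edits can be. Neither step gives a direction, so the expected outcome is a 1.2-fold lower number from compound 1 to compound 4 (0.09 log units; within the scatter), with no step beyond the scatter foreseen. For compound 4 the estimated value is 2500 nM, with an expected range from 300 nM to 20000 nM.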

Compound 4, concentration for 50% growth inhibition: 2410 nM
Estimate against measurement, compound 4: 1.0-fold (0.02 log units) above; measured number inside the range.
By their numbers in this assay, from the lowest: compound 2; then compounds 4 and 1 (each within the scatter of the next); then compound 3.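

In this assay the swap of 3,4-dimethoxyphenyl for 4-(trifluoromethoxy)phenyl gives a 1.3-fold lower number from compound 1 to compound 4 (0.11 log units; within the scatter) and so stays within the usual scatter. This position, where one added methoxy in compound 2 made a large difference, therefore also accepts a quite different group with no readable change. Nothing available explains why these two groups read alike. On these data alone, it remains open whether an amine or a carboxylic acid on this ring would also leave the number unchanged, and whether any other group here can match compound 2.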